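Carboxy in place of chloro: expected potency of compound 4

The source may hold more compounds than are shown below. What is called first, only, known or untested is meant among the compounds shown, and "the series" means these compounds.

Compound 2 `CCCCCCCCc1ccc(OC(C)C(=O)Cn2nnc(-c3ccc(Cl)cc3)n2)cc1` gives 35 nM in an assay on microsomes from brain for inhibition of Fatty-acid amide hydrolase 1 (Rattus norvegicus), read by fluorescence and HPLC, with a stated time of 60 min; a lower number here means a stronger inhibitor, a higher number a weaker inhibitor. Among the three measured members it stands second highest: compound 1 `CCCCCCCCc1ccc(OC(C)C(=O)Cn2nnc(-c3ccccc3)n2)cc1` gives 24 nM, and compound 3 `CC(Oc1ccc(Oc2ccc(C(F)(F)F)cc2)cc1)C(=O)Cn1nnc(-c2ccc(Cl)cc2)n1` gives 300 nM. The step of a 1.5-fold higher number from compound 1 to compound 2 (0.16 log units; within the scatter) shows that this position, para to a large group, accepts a small substituent without a shift beyond the scatter, whereas an 8.6-fold higher number from compound 2 to compound 3 (0.93 log units; beyond the scatter) concerns the other end of the molecule and does not bear on the present change. Compound 4 `CCCCCCCCc1ccc(OC(C)C(=O)Cn2nnc(-c3ccc(C(=O)O)cc3)n2)cc1` differs from compound 2 by carboxy in place of chloro on an aromatic carbon. Among the measured compounds shown here, no measured step places a carboxy here, so the expectation rests on the tolerance seen in a 1.5-fold higher number from compound 1 to compound 2 (0.16 log units; within the scatter) alone, with added uncertainty. Compound 4 is expected to give 80 nM, range 20 nM to 320 nM, in this assay. The estimated step is a 2.3-fold higher number from compound 2 to compound 4 (0.36 log units; beyond the scatter), a mild weakening at most.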

Compound 4, half-maximal inhibitory concentration: 50 nM
The estimate for compound 4 lay 1.6-fold (0.20 log units) above the measured number, and the stated range covers the measured number.
By their numbers in this assay, from the lowest: compounds 1, 2 and 4 (each within the scatter of the next, the first and the last beyond it); then compound 3.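

In this assay, the place para to a large group takes more than a small substituent: carboxy in place of chloro gives a 1.4-fold higher number from compound 2 to compound 4 (0.15 log units; within the scatter) and so brings a hydrogen-bond donor there with no shift beyond the scatter. Carboxy in place of hydrogen gives a 2.1-fold higher number from compound 1 to compound 4 (0.32 log units; beyond the scatter) and remains a modest loss. No evidence bears on the reason for this tolerance. 

Open: whether a methyl ester or an amine at this place behaves like carboxy, and whether carboxy is tolerated with 4-(trifluoromethyl)phenoxy in place of octyl.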